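Bromo for sulfanyl on the shared core

A few compounds are considered here, and "the series" means these few. Any claim that something is new, unique, unknown or untested is made for them only; others in the source may bear on it.

The series shares the core of compound 1 `CNc1nc2c(Cl)cc(Cl)cc2n1COCCO` and differs only at one aromatic carbon. In a functional assay on KB cells (Homo sapiens) for inhibition (a lower number here means a stronger inhibitor, a higher number a weaker inhibitor), compound 1 gives > 100000 nM, which is a limit of the assay and not a number. Compound 2 `OCCOCn1cnc2c(Cl)cc(Cl)cc21` gives in this assay > 100000 nM, again a limit. Compound 3 `OCCOCn1c(S)nc2c(Cl)cc(Cl)cc21` gives in this assay > 100000 nM, also a limit. Hence a step that the two limits leave unreadable from compound 1 to compound 2, a step that the two limits leave unreadable from compound 1 to compound 3 and a step that the two limits leave unreadable from compound 2 to compound 3 cannot be sized; all three values sit at the limit of > 100000 nM in this assay, at which 3 of the 3 values shown sit. Compound 3 thus stands at the limit, alongside compounds 1 and 2, with no readable gap among them. Compound 4 `OCCOCn1c(Br)nc2c(Cl)cc(Cl)cc21` differs from compound 3 by bromo in place of sulfanyl on an aromatic carbon. The measured steps bearing on this change, the three among compounds 1, 2 and 3, are all unreadable, so neither a direction nor a size can be taken from them; the expectation rests only on the limit shared by the three. For compound 4 the expected step of a number no higher from compound 3 to compound 4 (the limit leaves the size open) is none beyond the scatter, with a further limit of the assay the most likely outcome. Compound 4 is estimated at 100000 nM, in the range 20000 nM to 300000 nM.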

Compound 4, half-maximal inhibitory concentration: > 100000 nM
Compound 4: no number, only a limit; the forecaster's own chance of this, stated with the estimate: 80%; the middle value sits exactly at the limit.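

In this assay compound 4 gives > 100000 nM, a limit of the assay and not a number. The steps joining compound 4 to compounds 1, 2 and 3 therefore cannot be read. The compounds shown leave open how the groups on this aromatic carbon rank against one another, because all the values share one limit: the limit of > 100000 nM in this assay, at which 4 of the 4 values shown sit.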